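Swapping the aryl ester halogen in a flavone series

A few compounds are considered here, and "the series" means these few. Any claim that something is new, unique, unknown or untested is made for them only; others in the source may bear on it.

Of the compounds shown here, two of the shared core have been measured. Compound 1 `COC(=O)c1cccc(C)c1OC(=O)COc1cc(O)c2c(=O)cc(-c3ccccc3)oc2c1` gives 39100 nM in a functional assay on cells (T-cell, Mus musculus, strain BALB/c) for inhibition, read by MTT assay, with a stated time of 72 h; a lower number here means a stronger inhibitor, a higher number a weaker inhibitor. Compound 2 `COC(=O)c1ccc(Cl)cc1OC(=O)COc1cc(O)c2c(=O)cc(-c3ccccc3)oc2c1` gives 12400 nM in this assay, and stands as the lowest of the two numbers, separated from compound 1 by the step of a 3.2-fold lower number from compound 1 to compound 2 (0.50 log units; beyond the scatter). Compound 3 `COC(=O)c1c(Br)cccc1OC(=O)COc1cc(O)c2c(=O)cc(-c3ccccc3)oc2c1` has not yet been measured in this assay. It differs from compound 2 by a group of 11 heavy atoms (8 carbon, 2 oxygen, 1 bromine; one six-membered aromatic ring of carbon only) in place of a group of 11 heavy atoms (8 carbon, 2 oxygen, 1 chlorine; one six-membered aromatic ring of carbon only), on an oxygen next to a carbonyl group. Within the data shown here, the one measured step, from compound 1 to compound 2, also changed this group on an oxygen next to a carbonyl group and moved the number by a modest amount, so a change in this part of the molecule can matter; but both measured compounds are weak and the single example gives no direction for the present exchange. The step from compound 2 to compound 3 is therefore expected to be small, a 1.2-fold higher number from compound 2 to compound 3 (0.08 log units; within the scatter), likely within the scatter. Compound 3 is estimated at 15000 nM in this assay, with a range from 5000 nM to 45000 nM.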

Compound 3, half-maximal inhibitory concentration: 41700 nM
Compound 3: middle estimate off by 2.8-fold (0.44 log units), on the low side; the measured number falls inside the stated range.
By their numbers in this assay, from the lowest: compound 2; then compounds 1 and 3 (each within the scatter of the next).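

In this assay, the group on an oxygen next to a carbonyl group can move the number in either direction, and replacing the 5-chloro-2-(methoxycarbonyl)phenyl group of compound 2 with the bromine-bearing group of compound 3 costs what the earlier step had gained (a 3.4-fold higher number from compound 2 to compound 3 (0.53 log units; beyond the scatter)). A halogen on this group therefore does not by itself give the lower number: compound 3 carries one, yet it cannot be told apart from the methyl-bearing compound 1 (a 1.1-fold higher number from compound 1 to compound 3 (0.03 log units; within the scatter)), so of these three compounds, only compound 2 stands apart. Nothing available bears on why the chlorine-bearing and bromine-bearing groups differ.

The two halogen-bearing groups differ both in the halogen and in where it sits on the ring, so these compounds cannot show which of the two carries the step. Going by these compounds, it also remains open whether a fluorine or a methoxy group on this ring, or a carboxylic acid in place of the methoxycarbonyl group, would reach a lower number than compound 2 or leave the number where compound 1 and compound 3 stand.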